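The source may hold more compounds than are shown below. What is called first, only, known or untested is meant among the compounds shown, and "the series" means these compounds.

Measured in a functional assay on MGC-803 cells (Homo sapiens) for antiproliferative activity, read by MTT assay, with a stated time of 48 h; on this read-out lower numbers stand for stronger inhibition and higher numbers for weaker inhibition:

- compound 1 `COc1ccc2nc(SCC(=O)N(Cc3ccc(OC)c(O)c3)c3cc(OC)c(OC)c(OC)c3)sc2c1`: 71 nM
- compound 2 `COc1ccc(CN(C(=O)CSc2nc3cc(Cl)ccc3s2)c2cc(OC)c(OC)c(OC)c2)cc1O`: 85 nM

For the measured compounds named here, compound 2, at 85 nM, lies within the usual scatter of compound 1, the only other compound measured, so the two cannot be told apart in this assay. The next compound is compound 3 `COc1ccc(CN(C(=O)CSc2nc3c(C)cccc3s2)c2cc(OC)c(OC)c(OC)c2)cc1O`, which has not yet been measured. It carries 4-methyl-1,3-benzothiazol-2-yl in place of 5-chloro-1,3-benzothiazol-2-yl on a sulfur. The rest of the molecule is unchanged.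

Going by the values given here, one measured step bears on this change, the exchange of 6-methoxy-1,3-benzothiazol-2-yl for 5-chloro-1,3-benzothiazol-2-yl on the same sulfur. That step is a 1.2-fold higher number from compound 1 to compound 2 (0.08 log units; within the scatter), which stays within the scatter. Among the compounds with values here, no measured compound carries the 4-methyl-1,3-benzothiazol-2-yl group, and a single small step is thin evidence, so the expected range is kept wide. No shift beyond the scatter is expected in this assay, and no direction is favoured. The expected change is a 1.1-fold higher number from compound 2 to compound 3 (0.05 log units; within the scatter). For compound 3 the estimated value is 95 nM, with an expected range from 35 nM to 260 nM.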

Compound 3, half-maximal inhibitory concentration: 493 nM
The estimate for compound 3 lay 5.2-fold (0.72 log units) below the measured number; measured number above the stated range.
By their numbers in this assay, from the lowest: compounds 1 and 2 (each within the scatter of the next); then compound 3.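

In this assay the group on the sulfur, whose other neighbour is a saturated chain carbon, now proves able to move the number: 4-methyl-1,3-benzothiazol-2-yl in place of 5-chloro-1,3-benzothiazol-2-yl gives a 5.8-fold higher number from compound 2 to compound 3 (0.76 log units; beyond the scatter) and in place of 6-methoxy-1,3-benzothiazol-2-yl gives a 6.9-fold higher number from compound 1 to compound 3 (0.84 log units; beyond the scatter). The step between compound 1 and compound 2 had stayed within the scatter, so the position could have seemed indifferent to what the benzothiazolyl group carries, but compound 3 shows that it is not, even though the leaving 5-chloro-1,3-benzothiazol-2-yl and the entering group have the same count of heavy atoms. Nothing shown here accounts for this weaker inhibition.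

The compounds shown do not separate the methyl group itself from its place on the ring, a question that 6-methyl-1,3-benzothiazol-2-yl and 4-chloro-1,3-benzothiazol-2-yl would address. They also leave open how this position responds to an amine, as in 6-amino-1,3-benzothiazol-2-yl, or to a carboxylic acid.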